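The compounds below may be only part of what the source reports. "The series", "measured", "known", "first", "only" and "open" are said of these compounds alone.

Compound 1, `C=C1C[C@H]([C@@H](O)CCC)OC1=O`, was tested in a functional assay on HL-60 cells (Homo sapiens) for cytotoxicity (a higher number here means a weaker inhibitor, a lower number a stronger inhibitor), and gave 52600 nM. Compound 2, `C=C1C[C@H]([C@H](C)O)OC1=O`, differs from compound 1 by hydrogen in place of ethyl on a saturated chain carbon, two bonds along the chain from an oxygen on a saturated carbon and a saturated ring carbon and in this assay compound 2 gives 46800 nM, a step that reads a 1.1-fold lower number from compound 1 to compound 2 (0.05 log units; within the scatter). Compound 3, `C=C1C[C@H]([C@H](O)CCC)OC1=O`, shares its atoms and bonds with compound 1, the two differing only in that (the two compounds have the same atoms and bonds and differ only in configuration as drawn: 1 of 2 stereo elements differ; a stereocentre at a saturated chain carbon is drawn S in compound 1 and R in compound 3); in this assay compound 3 gives 51900 nM, and the step reads a 1.0-fold lower number from compound 1 to compound 3 (0.01 log units; within the scatter). Nothing in the data separates the two cores beyond (the fact that compounds 1 and 3 differ only in the configuration as drawn), and the three measured values sit together.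

Compound 4, `C=C1C[C@H]([C@@H](C)O)OC1=O`, has not yet been measured in this assay. It stands to compound 3 as compound 2 stands to compound 1: the change is hydrogen in place of ethyl on a saturated chain carbon, two bonds along the chain from an oxygen on a saturated carbon and a saturated ring carbon, the same change at the same place. Since the earlier step of a 1.1-fold lower number from compound 1 to compound 2 (0.05 log units; within the scatter) stayed within the scatter, and since the configuration step a 1.0-fold lower number from compound 1 to compound 3 (0.01 log units; within the scatter) also stayed within the scatter, compound 4 is expected to show a step of about a 1.1-fold lower number from compound 3 to compound 4 (0.04 log units; within the scatter). Compound 4 is therefore estimated at 47000 nM, most likely between 24000 nM and 95000 nM, pending the measurement.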

Compound 4, half-maximal inhibitory concentration in the HL-60 assay: 47300 nM
The estimate for compound 4 lay 1.0-fold (0.00 log units) below the measured number; the range from low to high includes it.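

In the HL-60 assay the new step reads a 1.1-fold lower number from compound 3 to compound 4 (0.04 log units; within the scatter), and the replacement of ethyl by hydrogen carries from the core of compound 1 to the core of compound 3 with no difference that can be told apart: the same change on two cores in the HL-60 assay, a 1.1-fold lower number (0.05 log units; within the scatter) from compound 1 to compound 2 and a 1.1-fold lower number (0.04 log units; within the scatter) from compound 3 to compound 4, 1.0-fold (0.01 log units) apart, within the scatter of two such steps In the HL-60 assay the configuration step on the shorter chain reads a 1.0-fold higher number from compound 2 to compound 4 (0.00 log units; within the scatter), so the stereocentre at the saturated chain carbon leaves the number as unmoved here as it does on the propyl compounds: the fact that compounds 2 and 4 differ only in the configuration as drawn This agreement rests on two small steps on cores of the same atoms and bonds, so it does not show that the change would carry to a core differing in constitution. In a physicochemical assay for lipophilicity (a higher number here means a more lipophilic compound, a lower number a more polar compound), compound 3 gives 1.59 and compound 4 gives 0.55. The same change is not small in the physicochemical assay, where it reads a number 1.04 log units lower from compound 3 to compound 4 (beyond the scatter).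

Only propyl and methyl chains are shown at this place, all with numbers close together in the HL-60 assay. On these data alone, whether a longer chain, a phenyl ring or an amine there would give a step beyond the scatter stays open.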